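This account rests on a few compounds, and the source may have more. Where it says the series, first, only, none or still open, it means among the compounds named here.

Of the compounds shown here, three sharing one core have been measured in an assay on isolated protein for inhibition of protein kinase C zeta type (Homo sapiens), with stated times of 1 h and 2.5 min, tested at 30 uM; on this read-out higher numbers stand for more inhibition at the one concentration tested (going by the name of the read-out) and lower numbers for less inhibition. Compound 1 `COCCOC(=O)c1c(-c2ccc(OC)c(OC)c2)csc1N` gives 57%, compound 2 `COCC(C)OC(=O)c1c(-c2ccc(OC)c(OC)c2)csc1N` gives 49%, and compound 3 `COc1ccc(-c2csc(N)c2C(=O)OCc2ccc(F)cc2)cc1OC` gives 2%. Compound 2 therefore sits together with compound 1, the two numbers lying within the scatter of each other, while compound 3 lies far lower. Compound 4 `COc1ccc(-c2csc(N)c2C(=O)OCc2cccc(C#N)c2)cc1OC` has not yet been measured. It differs from compound 2 in one place: 3-cyanobenzyl in place of 1-(methoxymethyl)ethyl on an oxygen next to a carbonyl group. The closest measured guide is the swap of the same 1-(methoxymethyl)ethyl group for 4-fluorobenzyl on the same oxygen, which gave a number 47 percentage points lower from compound 2 to compound 3 (beyond the scatter); the related swap gave a number 55 percentage points lower from compound 1 to compound 3 (beyond the scatter). Both of those changes lowered the read-out sharply, so a similarly large downward step in this assay is expected here, namely a number 41 percentage points lower from compound 2 to compound 4 (beyond the scatter). Compound 4 is accordingly estimated to give 8%, with a likely range from 0% to 30%.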

Compound 4, a percentage reported as inhibition, at one concentration (the size of the read-out at that concentration, not a potency): 70%
For compound 4 the middle estimate is 62 percentage points below the measured one; the whole stated range lies below it.
By their numbers in this assay, from the lowest: compound 3; then compounds 2 and 1 (each within the scatter of the next); then compound 4.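

In this assay, a benzyl group on this oxygen does not always lower the read-out: 3-cyanobenzyl in place of 1-(methoxymethyl)ethyl gives a number 21 percentage points higher from compound 2 to compound 4 (beyond the scatter). The sharp fall seen with 4-fluorobenzyl is therefore not shared by every benzyl group, and 3-cyanophenyl in place of 4-fluorophenyl gives a number 68 percentage points higher from compound 3 to compound 4 (beyond the scatter). The aromatic group also compares well with the methoxymethyl end of the chain, as 3-cyanophenyl in its place gives a number 13 percentage points higher from compound 1 to compound 4 (beyond the scatter).

Nothing available explains why these two aromatic groups differ so much. Going by these compounds, whether the nitrile itself, its place on the ring, or the loss of fluorine matters remains open, and a plain benzyl, 4-cyanobenzyl or 3-fluorobenzyl group on the same oxygen would help to separate these possibilities.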